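The source may report more compounds than this note shows. Statements on the series, on what has been measured and on what is new or still open speak of the compounds shown alone.

Of the compounds shown here, three that share one core have numbers so far in a functional assay on A549 cells (Homo sapiens) for antiproliferative activity, read by sulforhodamine B assay, with a stated time of 48 h; a higher number here means a weaker inhibitor, a lower number a stronger inhibitor. In this assay compound 1 `COc1cccc(/C=C/C(=O)C(=Cc2ccc(F)cc2)C(=O)/C=C/c2cccc(OC)c2OC)c1OC` gives 340 nM, compound 2 `COc1ccc(C=C(C(=O)/C=C/c2cccc(OC)c2OC)C(=O)/C=C/c2cccc(OC)c2OC)cc1OC` gives 170 nM, and compound 3 `COc1cccc(/C=C/C(=O)C(=Cc2cc(OC)c(OC)c(OC)c2)C(=O)/C=C/c2cccc(OC)c2OC)c1OC` gives 230 nM. Compound 3 therefore stands within the scatter of both other compounds, and the three cannot be ranked.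

Compound 4 `COc1cc(OC)c(C=C(C(=O)/C=C/c2cccc(OC)c2OC)C(=O)/C=C/c2cccc(OC)c2OC)c(OC)c1` has not yet been measured. Its structure has the same atoms as compound 3, joined differently, with 2,4,6-trimethoxyphenyl in place of 3,4,5-trimethoxyphenyl on a double-bonded chain carbon bound to a double-bonded chain carbon.

Going by the values given here, three measured steps bear on this change, since each alters the group at this place: a 2.0-fold lower number from compound 1 to compound 2 (0.30 log units; within the scatter), a 1.5-fold lower number from compound 1 to compound 3 (0.17 log units; within the scatter) and a 1.4-fold higher number from compound 2 to compound 3 (0.13 log units; within the scatter). Among the compounds with values here, all three stayed within the scatter, although no measured compound carries the 2,4,6-trimethoxyphenyl group. The expected change is therefore none beyond the scatter, with an estimated 1.1-fold higher number from compound 3 to compound 4 (0.04 log units; within the scatter). For compound 4 the estimated value is 250 nM, with an expected range from 100 nM to 650 nM.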

Compound 4, half-maximal inhibitory concentration: 630 nM
For compound 4 the middle estimate is 2.5-fold (0.40 log units) below the measured one, within the range that was stated.
By their numbers in this assay, from the lowest: compounds 2, 3, 1 and 4 (each within the scatter of the next, the first and the last beyond it).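

Going by these compounds alone, the step of a 2.7-fold higher number from compound 3 to compound 4 (0.44 log units; beyond the scatter) in this assay shows that this place responds to how the methoxy groups are arranged on the phenyl ring, even though the two compounds have the same atoms, and no earlier step here went beyond the scatter. The step of a 3.7-fold higher number from compound 2 to compound 4 (0.57 log units; beyond the scatter) also goes beyond the scatter, while the step of a 1.9-fold higher number from compound 1 to compound 4 (0.27 log units; within the scatter) stays within it, so the 2,4,6-trimethoxyphenyl group cannot be told apart from the 4-fluorophenyl group in these numbers. Nothing given here explains the difference between the two trimethoxyphenyl arrangements.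

As far as these compounds go, it remains open whether a 2,6-dimethoxyphenyl group would give a number close to that of compound 4 or that of compound 3. How a 4-hydroxyphenyl or 4-aminophenyl group would behave at this place is also unknown.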